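Bromo on the hydroxyphenyl arm: cytotoxicity working note

The source may report more compounds than this note shows. Statements on the series, on what has been measured and on what is new or still open speak of the compounds shown alone.

In an ADME assay on NIH3T3 cells (Mus musculus) for cytotoxicity, read by MTT assay, with a stated time of 24 h (on this read-out higher numbers stand for weaker inhibition and lower numbers for stronger inhibition), compound 1 `Cc1ccc(/C=N/NC(=O)CSc2nnc(-c3ccncc3)o2)cc1` gives 185000 nM and compound 2 `O=C(CSc1nnc(-c2ccncc2)o1)N/N=C/c1ccccc1O` gives 155000 nM. The step of a 1.2-fold lower number from compound 1 to compound 2 (0.08 log units; within the scatter) is within the scatter, so compound 2 and compound 1 sit together, neither apart from the other. Compound 3 `O=C(CSc1nnc(-c2ccncc2)o1)N/N=C/c1cc(Br)ccc1O` carries bromo in place of hydrogen on an aromatic carbon. For the measured compounds named here, no measured step touches this ring position; the one comparison available in this assay exchanged the whole aryl group and stayed within scatter. The step expected in this assay is a 1.3-fold lower number from compound 2 to compound 3 (0.11 log units; within the scatter), small, toward a lower number if anything. Compound 3 is expected to give 120000 nM, in the range 40000 nM to 300000 nM.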

Compound 3, half-maximal inhibitory concentration: 156000 nM
The estimate for compound 3 lay 1.3-fold (0.11 log units) below the measured number; low and high end bracket the measured number.
By their numbers in this assay, from the lowest: compounds 2, 3 and 1 (each within the scatter of the next).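

Bromo para to a hydroxy group is the first change read at this ring position, and in this assay the step is a 1.0-fold higher number from compound 2 to compound 3 (0.00 log units; within the scatter), so this single-atom addition leaves the number within the scatter. The whole-arm exchange gives the same picture, with a 1.2-fold lower number from compound 1 to compound 3 (0.07 log units; within the scatter). No measured evidence on these compounds bears on this result.

From the compounds shown here alone, whether an amine or a carboxylic acid in place of bromo would move the number beyond the scatter stays open. So does whether bromo would read the same without the hydroxy group.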